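This account rests on a few compounds, and the source may have more. Where it says the series, first, only, none or still open, it means among the compounds named here.

Two compounds of this urea series have a number in a functional assay on PC-9 cells (Homo sapiens) for inhibition, read by MTT assay, with a stated time of 48 h, tested at 10 uM; on this read-out lower numbers stand for less inhibition and higher numbers for more inhibition at the one concentration tested (going by the name of the read-out). Within the data shown here, compound 1 `COc1cc(NC(=O)Nc2cc(Nc3ccc(OC)c(C)c3)ncn2)cc(OC)c1` gives 62% in this assay, the lower of the two; compound 2 `COc1cc(Nc2cc(NC(=O)Nc3c(Cl)cccc3Cl)ncn2)cc(C(F)(F)F)c1` gives 88.5%, a difference beyond the scatter, though the two differ in more than one place and no single step connects them. Compound 3 `COc1cc(NC(=O)Nc2cc(Nc3cc(F)ccc3OC)ncn2)cc(OC)c1` keeps the core of compound 1 and carries 5-fluoro-2-methoxyphenyl in place of 4-methoxy-3-methylphenyl on a nitrogen on an aromatic ring. Among the measured compounds shown here, with no measured step of this kind to lean on, the change is expected to move this assay by a number 2 percentage points lower from compound 1 to compound 3 (within the scatter), a step not beyond the scatter in either direction. Compound 3 is therefore estimated at 60%, within 35% to 85%.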

Compound 3, a percentage reported as inhibition, at one concentration (the size of the read-out at that concentration, not a potency): 59.5%
Beside the measured number, compound 3's estimate is 0.5 percentage points above it; low and high end bracket the measured number.
By their numbers in this assay, from the lowest: compounds 3 and 1 (each within the scatter of the next); then compound 2.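

Among these compounds, on the nitrogen on an aromatic ring, in this assay, 5-fluoro-2-methoxyphenyl in place of 4-methoxy-3-methylphenyl gives a number 2.5 percentage points lower from compound 1 to compound 3 (within the scatter) and so provides the first measured step at this position. On the core of compound 1, this exchange of one substituted phenyl for another leaves the read-out within the scatter. Nothing at hand bears on why the two groups read alike.

On these data alone, the effect of a piperazine or a longer alkyl chain in place of the phenyl group on that nitrogen stays open. Also open, as far as these compounds go, is whether this step would read the same on the core of compound 2.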